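Replacing a Benzyl Link with an Amino Link

The compounds below may be only part of what the source reports. "The series", "measured", "known", "first", "only" and "open" are said of these compounds alone.

Compound 1 `CCc1ccccc1N(Cc1nnc(Cc2ccc(OC)cc2)o1)S(=O)(=O)c1ccc(C)cc1` gives 631 nM in a functional assay on CHO cells for antagonist activity at prostaglandin E2 receptor EP1 subtype (Homo sapiens), read by FLIPR and calcium flux (a higher number here means a weaker inhibitor, a lower number a stronger inhibitor), the highest of the three measured numbers. Compound 2 `COc1ccc(Cc2nnc(CN(c3cccc(Cl)c3C)S(=O)(=O)c3ccc(C)cc3)o2)cc1` gives 39.8 nM, and compound 3 `COc1ccc(Cc2nnc(CN(c3cccc(Cl)c3Cl)S(=O)(=O)c3ccc(C)cc3)o2)cc1` gives 39.8 nM; each differs from compound 1 only in the aryl group on the sulfonamide nitrogen, and a 16-fold lower number from compound 1 to compound 2 (1.20 log units; beyond the scatter) and a 16-fold lower number from compound 1 to compound 3 (1.20 log units; beyond the scatter) were both large, while no change at the digits printed from compound 2 to compound 3 (within the scatter) stayed within the scatter. Compound 4 `CCc1ccccc1N(Cc1nnc(CNc2ccc(OC)cc2)o1)S(=O)(=O)c1ccc(C)cc1` alters a different part of the molecule: (4-methoxyphenyl)amino in place of 4-methoxyphenyl on a saturated chain carbon bound to an aromatic carbon. For the measured compounds named here, none of the measured steps touches this position, so they give no guide to the size or direction of the change. With nothing to build on, the expected change is small, a 1.3-fold higher number from compound 1 to compound 4 (0.10 log units; within the scatter), and compound 4 is estimated at 800 nM, within a range of 200 nM to 4000 nM.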

Compound 4, inhibition constant: 794 nM
Estimate against measurement, compound 4: 1.0-fold (0.00 log units) above, and the stated range covers the measured number.
By their numbers in this assay, from the lowest: compounds 2 and 3 (each within the scatter of the next); then compounds 1 and 4 (each within the scatter of the next).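

In this assay the swap to (4-methoxyphenyl)amino gives a 1.3-fold higher number from compound 1 to compound 4 (0.10 log units; within the scatter) even though it adds a hydrogen-bond donor and a hydrogen-bond acceptor. For the compounds shown here, this is the first look at this end of the molecule, since the earlier steps changed only the aryl group on the sulfonamide nitrogen, and here the link can change with no step beyond the scatter. Still open, going by these compounds, is how an oxygen link or a longer chain would compare at this position, and whether the amino link behaves the same with 2,3-dichlorophenyl on the sulfonamide nitrogen. Nothing at hand explains the result.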